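This account rests on a few compounds, and the source may have more. Where it says the series, first, only, none or still open, it means among the compounds named here.

Series notes. Compound 1 `CCC(=O)Nc1cc(C(=O)Nc2ccc(N(C)C)cc2)ccc1OC(C)C` and compound 2 `CN1CCN(Cc2ccc(NC(=O)c3ccc(OCCCCl)c(N)c3)cc2C(F)(F)F)CC1` have both been run in a toxicity assay on Huh-7.5 cells (Homo sapiens) for inhibition, read by MTT assay, with a stated time of 96 h; on this read-out lower numbers stand for higher toxicity in this test and higher numbers for lower toxicity in this test. Compound 1 gives 80600 nM, while compound 2 gives 12900 nM; compound 2 therefore stands at the lower of the two numbers, with compound 1 lying beyond the scatter above it. Compound 3 `CCC(=O)Nc1cc(C(=O)Nc2ccc(CN3CCN(C)CC3)c(C(F)(F)F)c2)ccc1OCCCCl` is still to be measured in this assay. Relative to compound 2 the change is propanoyl in place of hydrogen on a nitrogen on an aromatic ring. For the measured compounds named here, compound 1 also carries the propanoylamino group and shows the higher of the two numbers, but it differs from compound 2 in several further places, so no single-change step is available as a guide. The expected step of a 1.7-fold higher number from compound 2 to compound 3 (0.23 log units; within the scatter) is a modest rise, close to the edge of the scatter. Compound 3 is accordingly estimated at 22000 nM in this assay, with a range from 8000 nM to 60000 nM.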

Compound 3, half-maximal cytotoxic concentration: 7870 nM
Estimate against measurement, compound 3: 2.8-fold (0.45 log units) above; the whole stated range lies above it.
By their numbers in this assay, from the lowest: compounds 3 and 2 (each within the scatter of the next); then compound 1.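

In this assay the replacement of amino by propanoylamino, on a nitrogen on an aromatic ring, gives a 1.6-fold lower number from compound 2 to compound 3 (0.21 log units; within the scatter) and so leaves no readable shift: on this core the position takes the propanoyl group with the number staying within the scatter. For the compounds shown here, this is the first single-change reading at this nitrogen, as compound 1 carries the same propanoylamino group but differs from compound 2 in several further places.

Open, on these data alone, is whether a longer acyl chain such as hexanoyl, or a methanesulfonyl group, on this nitrogen would also stay within the scatter. Also open, as far as these compounds go, is whether the same replacement behaves alike on a core without the chloropropoxy chain. No measurement at hand bears on why this step is as small as it is.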